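Moving a hydroxyl on a phenyl ring of topoisomerase inhibitors

A few compounds are considered here, and "the series" means these few. Any claim that something is new, unique, unknown or untested is made for them only; others in the source may bear on it.

Compound 1 `Oc1cccc(-c2cc(-c3cccs3)cc(-c3ccccc3O)n2)c1` and compound 2 `Oc1ccc(-c2cc(-c3cccs3)cc(-c3ccccc3O)n2)cc1` share one core. In an assay on isolated protein for inhibition of DNA topoisomerase 1 (Homo sapiens), with a stated time of 30 min, tested at 100 uM (on this read-out lower numbers stand for a weaker effect and higher numbers for a stronger effect at the one concentration tested), compound 1 gives 83.2% and compound 2 gives 72.2%. The change 4-hydroxyphenyl in place of 3-hydroxyphenyl on an aromatic carbon produced a number 11 percentage points lower from compound 1 to compound 2 (beyond the scatter). Compound 3 `Oc1ccc(-c2cc(-c3ccsc3)cc(-c3cccc(O)c3)n2)cc1` has a different core; how its core differs from that of compound 1 is not broken down here. In this assay compound 3 gives 17.1%. Compound 4 `Oc1ccc(-c2cc(-c3ccsc3)cc(-c3ccc(O)cc3)n2)cc1` arises from compound 3 by 4-hydroxyphenyl in place of 3-hydroxyphenyl on an aromatic carbon. This is the same kind of change as the earlier one, though the surroundings differ: the group is meta to a 4-hydroxyphenyl group and a thiophen-3-yl group, not meta to a 2-hydroxyphenyl group and a thiophen-2-yl group. Among the measured compounds shown here, a similar downward step is expected, a number 7.1 percentage points lower from compound 3 to compound 4 (within the scatter), resting on the single earlier pair, and limited by how little room compound 3 leaves. Compound 4 is therefore estimated at 10%, from 0% to 28%.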

Compound 4, a percentage reported as inhibition, at one concentration (the size of the read-out at that concentration, not a potency): 61.7%
Beside the measured number, compound 4's estimate is 51.7 percentage points below it, outside the stated range (above it).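

In this assay, putting 4-hydroxyphenyl in place of 3-hydroxyphenyl gave a number 44.6 percentage points higher from compound 3 to compound 4 (beyond the scatter). The change therefore did not carry over from one core to the other, differing in both direction and size: the same change on two cores in this assay, a number 11 percentage points lower (beyond the scatter) from compound 1 to compound 2 and a number 44.6 percentage points higher (beyond the scatter) from compound 3 to compound 4, 55.6 percentage points apart, beyond the scatter of two such steps

So the result of this swap depends on the core in these two pairs, and a step measured on one core cannot simply be transferred to the other, but two pairs do not show which feature of the cores is responsible. The compounds shown leave open whether the thiophen-3-yl group or the 4-hydroxyphenyl group of compound 3 matters more for this reversal. They also leave open how an amine or a carboxylic acid in place of the hydroxyl on this ring would behave.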